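This account rests on a few compounds, and the source may have more. Where it says the series, first, only, none or still open, it means among the compounds named here.

Working notes on the series, read in a physicochemical assay for lipophilicity, measured as octanol-water partition, at pH 7.4; a higher number here means a more lipophilic compound, a lower number a more polar compound. Compound 1 `Cc1ccc2[nH]c(C(=O)N[C@H]3CN(S(=O)(=O)c4cnccn4)C[C@@H]3C(=O)NCCN(C)C)cc2c1` gives 1, compound 2 `Cc1ccc2[nH]c(C(=O)N[C@H]3CN(S(=O)(=O)C4CCOCC4)C[C@@H]3C(=O)NCCN(C)C)cc2c1` gives 1, and compound 3 `Cc1ccc2[nH]c(C(=O)N[C@H]3CCN(S(=O)(=O)c4cccnc4)C[C@@H]3C(=O)NCCN(C)C)cc2c1` gives 1.3, which places compound 3 within the scatter of both others. Compound 4 `Cc1ccc2[nH]c(C(=O)N[C@H]3CCN(C(=O)c4cccnc4)C[C@@H]3C(=O)NCCN(C)C)cc2c1` has (pyridin-3-yl)carbonyl in place of (pyridin-3-yl)sulfonyl on an amine nitrogen in a ring. Going by the values given here, the one measured step shows no change at the digits printed from compound 1 to compound 2 (within the scatter), with oxan-4-yl in place of pyrazin-2-yl on a sulfonyl sulfur. Among the compounds with values here, that step keeps the sulfonyl, and no measured step exchanges it for carbonyl, so its guidance is loose. A small downward move, not clearly beyond the scatter, is expected: a number 0.30 log units lower from compound 3 to compound 4 (within the scatter). The estimate for compound 4 is 1, within an expected range of 0.5 to 1.4.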

Compound 4, distribution coefficient: 0.7
The estimate for compound 4 lay 0.30 log units above the measured number, and the stated range covers the measured number.
By their numbers in this assay, from the lowest: compounds 4, 1, 2 and 3 (each within the scatter of the next, the first and the last beyond it).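

In this assay, going by these compounds alone, (pyridin-3-yl)carbonyl in place of (pyridin-3-yl)sulfonyl on the amine nitrogen in the ring gives a number 0.60 log units lower from compound 3 to compound 4 (beyond the scatter) and is the only step here beyond the scatter. The other step keeps the sulfonyl and changes only the group on it, so exchanging the sulfonyl itself is the one change shown to move this read-out. Nothing available accounts for the size of this step. Open, from the compounds shown here alone, is how a urea or a methylene link on the same amine nitrogen would read, and whether the step holds with oxan-4-yl in place of pyridin-3-yl.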